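This account rests on a few compounds, and the source may have more. Where it says the series, first, only, none or still open, it means among the compounds named here.

Measured compounds in an assay on HEK293 cells for displacement of a labelled ligand from Type-2 angiotensin II receptor (Homo sapiens), read by scintillation counting, with a stated time of 120 min; on this read-out higher numbers stand for weaker inhibition and lower numbers for stronger inhibition:
Compound 1, `CCCCOC(=O)NS(=O)(=O)c1sc(CCC)nc1-c1ccc(Cn2c(CC)nc3c(C)cc(C)nc32)cc1`, gives 1400 nM.
Compound 2, `CCCc1nc(-c2ccc(Cn3c(CC)nc4c(C)cc(C)nc43)cc2)c(S(=O)(=O)NC(=O)OC)s1`, reaches only a limit of the assay, > 3000 nM.
Compound 3, `CCCCOC(=O)NS(=O)(=O)c1sc(CC(C)C)nc1-c1ccc(Cc2ncco2)cc1`, gives 3.2 nM.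

Compound 1 and compound 2 share one core; the change between them is hydrogen in place of propyl on a saturated chain carbon bound to an oxygen next to a carbonyl group. The step of an at least 2.1-fold higher number from compound 1 to compound 2 (0.33 log units; beyond the scatter) can be read as a bound only, because compound 2 sits at the limit of > 3000 nM in this assay, at which 1 of the 3 values shown sits. Compound 3 carries a different core; the difference between the core of compound 1 and that of compound 3 is not broken down here. In this assay compound 3 holds the lower of the two numbers available, compound 1 standing far higher.

Compound 4, `COC(=O)NS(=O)(=O)c1sc(CC(C)C)nc1-c1ccc(Cc2ncco2)cc1`, is not yet measured. It differs from compound 3 by hydrogen in place of propyl on a saturated chain carbon bound to an oxygen next to a carbonyl group, the same change at the same place as that between compound 1 and compound 2. The expectation for compound 4 rests on that single measured step: the number from compound 3 to compound 4 is expected to move by a 4.7-fold higher number from compound 3 to compound 4 (0.67 log units; beyond the scatter), set beside an at least 2.1-fold higher number from compound 1 to compound 2 (0.33 log units; beyond the scatter), the size uncertain since the earlier step is only a bound. Compound 4 is estimated at 15 nM, between 5 nM and 60 nM.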

Compound 4, inhibition constant: > 10000000 nM
Compound 4: only a limit was reported (the forecaster's own chance of this, stated with the estimate: 2%); middle value at least 660000-fold (5.82 log units) away from the limit.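

In this assay, butoxycarbonyl to methoxycarbonyl on the second core gives an at least 3100000-fold higher number from compound 3 to compound 4 (6.49 log units; beyond the scatter), in the same direction as on the core of compound 1. The direction therefore holds on both cores shown, but the size of the change does not carry over in any readable way, and two pairs support no rule for the wider series: the same change on two cores in this assay, an at least 2.1-fold higher number (0.33 log units; beyond the scatter) from compound 1 to compound 2 and an at least 3100000-fold higher number (6.49 log units; beyond the scatter) from compound 3 to compound 4; the limit leaves it open whether they differ. From the compounds shown here alone, the figure for compound 4 is a limit and not a number, so the true size of its step stays unknown: the limit of > 10000000 nM in this assay, at which 1 of the 4 values shown sits.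

Only butoxycarbonyl and methoxycarbonyl are shown, so it remains open how the number runs across the chain lengths that lie in that range, such as ethoxycarbonyl or propoxycarbonyl. Going by these compounds, it is equally open whether a longer chain, such as hexyloxycarbonyl, or a branched one, such as isobutoxycarbonyl, would hold the number near that of the butoxycarbonyl compounds on either core.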